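Trimming a tert-butyl to isopropyl on a weak urea

The source may report more compounds than this note shows. Statements on the series, on what has been measured and on what is new or still open speak of the compounds shown alone.

Measured compounds:
Compound 1, `COc1ccc(N2CCN(C(=O)Nc3nc4ccc(F)cc4s3)CC2)nn1`, > 10000 nM
Compound 2, `CC(C)(C)c1ccc(NC(=O)N2CCN(c3nncc4ccccc34)CC2)cc1`, > 10000 nM

Of the compounds shown here, two have so far been tested in an assay on HEK293 cells for inhibition of transient receptor potential cation channel subfamily V member 1 (Homo sapiens), read by FLIPR; a lower number here means a stronger inhibitor, a higher number a weaker inhibitor. For compound 1 the outcome is a limit of the assay rather than a number: compound 1 gives > 10000 nM. The same holds for compound 2, whose result is also a limit and not a number: compound 2 gives > 10000 nM. Compound 2 therefore stands at the limit of > 10000 nM in this assay, at which 2 of the 2 values shown sit, and on these numbers nothing separates compound 2 from compound 1.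

Compound 3, `CC(C)c1ccc(NC(=O)N2CCN(c3nncc4ccccc34)CC2)cc1`, has not yet been measured. It differs from compound 2 in a single place: hydrogen in place of methyl on a saturated chain carbon bound to an aromatic carbon and two saturated chain carbons. Going by the values given here, no pair of measured compounds shows how much such a small trimming shifts the read-out here, so no measured step can guide the size of the change. Given that compound 2 sits at the limit of > 10000 nM in this assay, at which 2 of the 2 values shown sit, compound 3 is expected to stay within the scatter of compound 2 in this assay, with a step that the limit leaves unreadable from compound 2 to compound 3, most likely again as a limit. The estimate for compound 3 is 15000 nM, expected to fall between 5000 nM and 50000 nM.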

Compound 3, half-maximal inhibitory concentration: > 10000 nM
Compound 3 gave a limit, no number (the forecaster's own chance of this, stated with the estimate: 85%); the middle value is on the limit's open side.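

In this assay compound 3 gives a limit and not a number, and so does compound 2, so the step from tert-butyl to isopropyl between these two compounds cannot be read: the limit of > 10000 nM in this assay, at which 3 of the 3 values shown sit.

The compounds shown leave open how far such a trimming moves the read-out, and which structure would give a measurable number in this assay at all.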